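Swapping methyl for isopropyl on the saturated ring carbon

This account rests on a few compounds, and the source may have more. Where it says the series, first, only, none or still open, it means among the compounds named here.

Of the compounds shown here, three sharing one core have been measured in an assay on Sf9 cells for inhibition of serine/threonine-protein kinase 4 (Homo sapiens), read by luminescence and ADP-Glo, with a stated time of 1 h, in the presence of a further agent that is not named here; a higher number here means a weaker inhibitor, a lower number a stronger inhibitor. Compound 1 `CN1C(=O)C(C2CC2)N(C)c2nc(Nc3ccc(S(N)(=O)=O)cc3)ncc21` gives 136 nM. Compound 2 `CN1CC(=O)N(C)c2cnc(Nc3ccc(S(N)(=O)=O)cc3)nc21` gives 495 nM. Compound 3 `CC1C(=O)N(C)c2cnc(Nc3ccc(S(N)(=O)=O)cc3)nc2N1C` gives 313 nM, the second highest of the three numbers; its nearest neighbour is compound 2, within the scatter, and its furthest is compound 1, beyond the scatter.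

Compound 4 `CC(C)C1C(=O)N(C)c2cnc(Nc3ccc(S(N)(=O)=O)cc3)nc2N1C` differs from compound 3 in one place: isopropyl in place of methyl on a saturated ring carbon. Among the compounds with values here, two measured steps touch the same saturated ring carbon. Going from cyclopropyl to methyl there gave a 2.3-fold higher number from compound 1 to compound 3 (0.36 log units; beyond the scatter), and going from cyclopropyl to hydrogen gave a 3.6-fold higher number from compound 1 to compound 2 (0.56 log units; beyond the scatter). The smallest change, hydrogen to methyl, gave only a 1.6-fold lower number from compound 2 to compound 3 (0.20 log units; within the scatter). Across these three compounds, the cyclopropyl group at this carbon goes with the lowest number, while hydrogen and methyl sit close together at higher numbers. Isopropyl is a third group placed at that same carbon, and the data do not show it directly. A modest step toward a lower number is therefore expected, of about the size seen when methyl was replaced by cyclopropyl, which means an estimated 1.8-fold lower number from compound 3 to compound 4 (0.27 log units; within the scatter). Compound 4 is expected to give 170 nM in this assay, with a range from 75 nM to 400 nM.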

Compound 4, half-maximal inhibitory concentration: 254 nM
For compound 4 the middle estimate is 1.5-fold (0.17 log units) below the measured one; low and high end bracket the measured number.
By their numbers in this assay, from the lowest: compounds 1, 4, 3 and 2 (each within the scatter of the next, the first and the last beyond it).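

In this assay, the step from methyl to isopropyl on the saturated ring carbon gives a 1.2-fold lower number from compound 3 to compound 4 (0.09 log units; within the scatter), so this carbon carries three heavy atoms in its substituent about as well as one. Compound 4 also cannot be separated from either end of the series: replacing hydrogen gives a 1.9-fold lower number from compound 2 to compound 4 (0.29 log units; within the scatter), and replacing cyclopropyl gives a 1.9-fold higher number from compound 1 to compound 4 (0.27 log units; within the scatter), even though the ends themselves are separated by a 3.6-fold higher number from compound 1 to compound 2 (0.56 log units; beyond the scatter). The isopropyl result therefore adds a group that fits within the narrow range seen so far, and no measurement shown here explains how these groups differ in their effect.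

From the compounds shown here alone, every group at this carbon so far is either hydrogen or made only of carbon and hydrogen, so it remains open whether an amine, a hydroxyl or a carboxylic acid would shift the number well beyond the scatter. A longer chain such as n-butyl, or a phenyl ring, would show whether this carbon keeps accepting larger groups or whether the number climbs once they grow past isopropyl.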